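The source may hold more compounds than are shown below. What is called first, only, known or untested is meant among the compounds shown, and "the series" means these compounds.

Compound 1 `COc1cc(C(O)(C(F)(F)F)C(F)(F)F)cnc1N1CCN(S(=O)(=O)c2ccc(N)nc2)CC1` bears a methoxy group on the shared core. In an ADME assay (liver) for metabolic stability, with Liver microsome (Rattus norvegicus) as the target, using microsomes and NADPH, with a stated time of 30 min, tested at 1 uM (on this read-out higher numbers stand for fast clearance and lower numbers for slow clearance), compound 1 gives only a limit, < 14 mL.min-1.g-1, so no number is known for it. It sits at the limit of < 14 mL.min-1.g-1 in this assay, at which 1 of the 3 values shown sits. Compound 2 `CC(C)n1cc(-c2cc(C(O)(C(F)(F)F)C(F)(F)F)cnc2N2CCN(S(=O)(=O)c3ccc(N)nc3)CC2)cn1` gives 198 mL.min-1.g-1 in this assay, and compound 3 `CC(C)(C)n1cc(-c2cc(C(O)(C(F)(F)F)C(F)(F)F)cnc2N2CCN(S(=O)(=O)c3ccc(N)nc3)CC2)cn1` gives 459 mL.min-1.g-1. The step of an at least 14-fold higher number from compound 1 to compound 2 (1.15 log units; beyond the scatter) and the step of an at least 32-fold higher number from compound 1 to compound 3 (1.51 log units; beyond the scatter) both move far beyond the scatter, while the step of a 2.3-fold higher number from compound 2 to compound 3 (0.37 log units; beyond the scatter) adds a modest further rise. Compound 4 `Nc1ccc(S(=O)(=O)N2CCN(c3ncc(C(O)(C(F)(F)F)C(F)(F)F)cc3-c3cccc(F)c3)CC2)cn1` differs from compound 1 by 3-fluorophenyl in place of methoxy on an aromatic carbon. The two measured exchanges of the methoxy for a ring on an aromatic carbon are the ones that bear on this change, and both were large in the same direction. Because the step of an at least 14-fold higher number from compound 1 to compound 2 (1.15 log units; beyond the scatter) was already so large, compound 4 is expected to show an at least 14-fold higher number from compound 1 to compound 4 (1.15 log units; beyond the scatter). Compound 4 is therefore estimated at 200 mL.min-1.g-1, with a range from 60 mL.min-1.g-1 to 600 mL.min-1.g-1.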

Compound 4, intrinsic clearance in microsomes: 52 mL.min-1.g-1
The estimate for compound 4 lay 3.8-fold (0.59 log units) above the measured number; the measured number lies below the stated range.
By their numbers in this assay, from the lowest: compound 4; then compound 2; then compound 3. At a limit, below all of these: compound 1.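

In this assay, a ring in place of the methoxy does not bring one fixed rise: the 3-fluorophenyl gives an at least 3.7-fold higher number from compound 1 to compound 4 (0.56 log units; beyond the scatter), while the two N-alkyl pyrazoles stand well higher, as a 3.8-fold lower number from compound 2 to compound 4 (0.58 log units; beyond the scatter) and an 8.8-fold lower number from compound 3 to compound 4 (0.95 log units; beyond the scatter) show. The very high numbers of compound 2 and compound 3 therefore go with those two pyrazoles and not with any aromatic ring at this position, so the identity of the ring counts here as well as its presence. The rise over the methoxy remains a minimum, since compound 1 stands only at a limit: the limit of < 14 mL.min-1.g-1 in this assay, at which 1 of the 4 values shown sits.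

As far as these compounds go, how an unsubstituted phenyl or a 1-methylpyrazole would read at this position stays open, so the part played by the fluorine or by the size of the alkyl group cannot be separated. From the compounds shown here alone, whether an amine or a nitrile in place of the methoxy would stay close to compound 1 is also open.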